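This account rests on a few compounds, and the source may have more. Where it says the series, first, only, none or still open, it means among the compounds named here.

Measured so far in a physicochemical assay for solubility, in phosphate buffer, measured as kinetic solubility, at pH 7.4; a lower number here means a less soluble compound, a higher number a more soluble compound:

Compound 1 `Cc1oc(-c2ccccc2Cl)nc1CN1CCC(C(=O)NCCCN2C[C@H](C)C[C@H](C)C2)CC1` gives > 72 ug/mL, which is a limit of the assay and not a number.
Compound 2 `Cc1ccccc1-c1nc(CN2CCC(C(=O)NCCCN3CCCC(C(C)C)C3)CC2)c(C)o1` gives > 71 ug/mL, again a limit rather than a number.
Compound 3 `CCCN(CCC)CCNC(=O)C1CCN(Cc2nc(-c3ccccc3C)oc2C)CC1` gives > 65 ug/mL, also a limit.

Compound 1 therefore does not stand at a measured point but at a limit, and the two other values shown are limits as well (the limit of > 72 ug/mL in this assay, at which 1 of the 3 values shown sits, (the limit of > 71 ug/mL in this assay, at which 1 of the 3 values shown sits), (the limit of > 65 ug/mL in this assay, at which 1 of the 3 values shown sits)). Going by the values given here, the one step between measured compounds, a step that the two limits leave unreadable from compound 2 to compound 3, cannot be read in size, since both ends sit at limits. The change from compound 1 to compound 4 `Cc1ccc(-c2nc(CN3CCC(C(=O)NCCCN4C[C@H](C)C[C@H](C)C4)CC3)c(C)o2)cc1` is 4-methylphenyl in place of 2-chlorophenyl on an aromatic carbon. Among the compounds with values here, no measured step bears on this change directly; the only step available, from compound 2 to compound 3, concerns the amine end of the chain and is unreadable. Since every measured value here sits at a limit, the account expects compound 4 to sit at or beyond the limit as well, with a step that the limit leaves unreadable from compound 1 to compound 4, that is no change beyond the scatter. The estimate for compound 4 in this assay is 80 ug/mL, within 40 ug/mL to 200 ug/mL.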

Compound 4, solubility: > 69 ug/mL
Compound 4: no number, only a limit; the forecaster's own chance of this, stated with the estimate: 75%; the middle value is on the limit's open side.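

In this assay compound 4 gives > 69 ug/mL, which is a limit of the assay and not a number. Compound 1 also stands at a limit, so the step between these two compounds cannot be read. The compounds shown leave open whether 4-methylphenyl and 2-chlorophenyl differ at all in this read-out.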